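A hydroxy group added to a benzamide resting at the limit

A few compounds are considered here, and "the series" means these few. Any claim that something is new, unique, unknown or untested is made for them only; others in the source may bear on it.

Compound 1 `COc1ccc(Br)cc1C(=O)Nc1ccc(Sc2nc3ccccc3s2)cc1` in an assay for inhibition of HSP60/HSP10 (Homo sapiens), with a stated time of 60 min; on this read-out lower numbers stand for stronger inhibition and higher numbers for weaker inhibition: > 100000 nM, a limit of the assay rather than a number.
Compound 2 `O=C(Nc1ccc(Sc2nc3ccccc3s2)cc1)c1cc(Br)cc(Br)c1` in this assay: > 100000 nM, again a limit.
Compound 3 `O=C(Nc1ccc(Sc2nc3ccccc3s2)cc1)c1ccccc1` in this assay: > 100000 nM, also a limit.

Compound 3 therefore stands nowhere in particular among the three: every value shown sits at the limit of > 100000 nM in this assay, at which 3 of the 3 values shown sit. The three steps among them, a step that the two limits leave unreadable from compound 1 to compound 2, a step that the two limits leave unreadable from compound 1 to compound 3 and a step that the two limits leave unreadable from compound 2 to compound 3, are unreadable, so they give no sense of how much a change on the ring attached to the carbonyl can move the result.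

Compound 4 `O=C(Nc1ccc(Sc2nc3ccccc3s2)cc1)c1ccccc1O` differs from compound 3 by hydroxy in place of hydrogen on an aromatic carbon. Among the compounds with values here, no measured step bears on this change in a readable way, and none of the three compounds has a number to start from. With every measured compound at the limit, compound 4 is expected to remain at the limit as well, so the step of a number no higher from compound 3 to compound 4 (the limit leaves the size open) is expected to be none beyond the scatter. Compound 4 is estimated at 100000 nM, with a range from 20000 nM to 300000 nM.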

Compound 4, half-maximal inhibitory concentration: > 100000 nM
Compound 4 gave a limit, no number; the forecaster's own chance of this, stated with the estimate: 85%; the middle value lies on the limit itself.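

In this assay compound 4 gives > 100000 nM, a limit of the assay and not a number. Its steps from compound 1, compound 2 and compound 3 cannot be read. Whether any change on the ring attached to the carbonyl can move the result stays open, with every value at one limit: the limit of > 100000 nM in this assay, at which 4 of the 4 values shown sit.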